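Dimethylamino to Isobutylamino: Expected Cytotoxicity of Compound 4

This account rests on a few compounds, and the source may have more. Where it says the series, first, only, none or still open, it means among the compounds named here.

In an ADME assay on CCRF-HSB-2 cells (Homo sapiens) for cytotoxicity, with a stated time of 7 days (on this read-out lower numbers stand for higher toxicity in this test and higher numbers for lower toxicity in this test), the three measured compounds give only limits.
Compound 1 `CCCCCCCCOc1nc(N)nc2c1ncn2/C=C1/CC1(CO)CO`: > 20000 nM, a limit of the assay.
Compound 2 `CN(C)c1nc(N)nc2c1ncn2/C=C1/CC1(CO)CO`: > 20000 nM, a limit of the assay.
Compound 3 `Nc1nc2c(ncn2/C=C2/CC2(CO)CO)c(=O)[nH]1`: > 20000 nM, a limit of the assay.

Compound 2 thus stands only at a limit, and no number places it against compound 1 or compound 3, as the limit of > 20000 nM in this assay, at which 3 of the 3 values shown sit, shows. For the measured compounds named here, the one step between compounds differing in a single place, a step that the two limits leave unreadable from compound 1 to compound 2, is unreadable in size and direction. Compound 4 `CC(C)CNc1nc(N)nc2c1ncn2/C=C1/CC1(CO)CO` differs from compound 2 by isobutylamino in place of dimethylamino on an aromatic carbon. Going by the values given here, no measured step bears readably on this change, and every value seen sits at the limit, so no step beyond the scatter is expected in this assay. The expected step is a step that the limit leaves unreadable from compound 2 to compound 4. Compound 4 is therefore estimated at 30000 nM, between 15000 nM and 100000 nM, most likely reported again only as a limit.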

Compound 4, half-maximal cytotoxic concentration: > 20000 nM
Compound 4 was reported as a limit; the forecaster's own chance of this, stated with the estimate: 85%; the middle value lies beyond the limit too.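

In this assay compound 4 gives only a limit of the assay (> 20000 nM). No step to compound 4 from compound 1 or compound 2 can be read: the limit of > 20000 nM in this assay, at which 4 of the 4 values shown sit.

The compounds shown leave open whether the groups at this place differ at all in cytotoxicity.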